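The source may report more compounds than this note shows. Statements on the series, on what has been measured and on what is new or still open speak of the compounds shown alone.

Compound 1 `O=[N+]([O-])c1ccc(CSc2nnc(-c3ccc4c(c3)OCCO4)n2-c2ccccc2)cc1` is a small set of three close relatives. In a functional assay on HeLa cells (Homo sapiens) for antiproliferative activity, read by MTT assay, with a stated time of 24 h (a lower number here means a stronger inhibitor, a higher number a weaker inhibitor), compound 1 gives 36200 nM, the second highest of the three numbers; compound 2 `Fc1ccccc1CSc1nnc(-c2ccc3c(c2)OCCO3)n1-c1ccccc1` gives 24300 nM and compound 3 `Fc1ccc(CSc2nnc(-c3ccc4c(c3)OCCO4)n2-c2ccccc2)cc1` gives 46900 nM. The unmeasured compound 4 `Brc1ccccc1CSc1nnc(-c2ccc3c(c2)OCCO3)n1-c1ccccc1` differs from compound 1 in one place: 2-bromophenyl in place of 4-nitrophenyl on a saturated chain carbon bound to a sulfur. The closest measured step is the one from a 1.5-fold lower number from compound 1 to compound 2 (0.17 log units; within the scatter), and the related steps of a 1.3-fold higher number from compound 1 to compound 3 (0.11 log units; within the scatter) and a 1.9-fold higher number from compound 2 to compound 3 (0.29 log units; within the scatter) were equally modest. A change of a group on this chain carbon therefore is expected to shift this assay little, if at all. For compound 4 the expected value is 27000 nM, between 11000 nM and 65000 nM, a step of a 1.3-fold lower number from compound 1 to compound 4 (0.13 log units; within the scatter).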

Compound 4, half-maximal inhibitory concentration: > 100000 nM
Compound 4 ended at the assay's limit; the forecaster's own chance of this, stated with the estimate: 5%; middle value at least 3.7-fold (0.56 log units) away from the limit.
By their numbers in this assay, from the lowest: compounds 2, 1 and 3 (each within the scatter of the next). At a limit, above all of these: compound 4.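

In this assay compound 4 stands at a limit, not at a number: the limit of > 100000 nM in this assay, at which 1 of the 4 values shown sits.

Compounds 1, 2 and 3 made the group on this chain carbon look unimportant, yet this position does respond: the result is an at least 2.7-fold higher number from compound 1 to compound 4 (0.44 log units; beyond the scatter) and an at least 2.1-fold higher number from compound 3 to compound 4 (0.32 log units; beyond the scatter). Exchanging only fluoro for bromo on the aromatic carbon gives an at least 4.1-fold higher number from compound 2 to compound 4 (0.61 log units; beyond the scatter), so a single-atom change here is enough to move beyond the scatter.

From the compounds shown here alone, the true size of these steps stays open. So does whether the drop belongs to bromo alone, which a chloro group or an amine on this ring could help to test.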